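From sulfonyl to butylcarbamoyl on the amine nitrogen

The compounds below may be only part of what the source reports. "The series", "measured", "known", "first", "only" and "open" are said of these compounds alone.

In a functional assay for inhibition, with Homo sapiens as the target (on this read-out lower numbers stand for stronger inhibition and higher numbers for weaker inhibition), compound 1 `O=C(O)CCNC(=O)c1ccc2c(c1)C(=O)N(CCC1CCNCC1)C2` gives 27 nM, compound 2 `CC(C)CS(=O)(=O)N[C@@H](CNC(=O)c1ccc2c(c1)C(=O)N(CCC1CCNCC1)C2)C(=O)O` gives 9 nM and compound 3 `CCOCCS(=O)(=O)N[C@@H](CNC(=O)c1ccc2c(c1)C(=O)N(CCC1CCNCC1)C2)C(=O)O` gives 8 nM. Compound 3 thus stands level with compound 2 and clearly under compound 1.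

Compound 4 `CCCCNC(=O)N[C@@H](CNC(=O)c1ccc2c(c1)C(=O)N(CCC1CCNCC1)C2)C(=O)O` has butylcarbamoyl in place of (2-ethoxyethyl)sulfonyl on an amine nitrogen.

Two steps show what adding the substituted amino group did: a 3.0-fold lower number from compound 1 to compound 2 (0.48 log units; beyond the scatter) and a 3.4-fold lower number from compound 1 to compound 3 (0.53 log units; beyond the scatter). Exchanging the sulfonyl chain gave only a 1.1-fold lower number from compound 2 to compound 3 (0.05 log units; within the scatter). Among the measured compounds shown here, no measured compound tests loss of the sulfonyl itself, so the estimate is loose.

In this assay no change beyond the scatter is expected, the estimated step being a 1.3-fold higher number from compound 3 to compound 4 (0.10 log units; within the scatter). The estimate for compound 4 is 10 nM, with an expected range of 4 nM to 27 nM.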

Compound 4, half-maximal inhibitory concentration: 16 nM
For compound 4 the middle estimate is 1.6-fold (0.20 log units) below the measured one, within the range that was stated.
By their numbers in this assay, from the lowest: compounds 3, 2, 4 and 1 (each within the scatter of the next, the first and the last beyond it).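

On the amine nitrogen, butylcarbamoyl stays level with both sulfonyl groups in this assay, with a 2.0-fold higher number from compound 3 to compound 4 (0.30 log units; within the scatter) and a 1.8-fold higher number from compound 2 to compound 4 (0.25 log units; within the scatter). However, a 1.7-fold lower number from compound 1 to compound 4 (0.23 log units; within the scatter) leaves the (butylcarbamoyl)amino compound within the scatter of the unsubstituted chain, whereas both sulfonyl compounds stood beyond it, so a gain over compound 1 is not established for this change. No supporting data bear on this result.

Still open, on these data alone, is whether the sulfonyl or carbamoyl link or the attached chain governs the read-out. A phenylcarbamoyl or methylsulfonyl group on this nitrogen would help separate the two.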